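Swapping a Hydroxymethyl for an Amino on a Shared Core

The source may hold more compounds than are shown below. What is called first, only, known or untested is meant among the compounds shown, and "the series" means these compounds.

Measured so far in an ADME assay on microsomes from liver (Homo sapiens) for metabolic stability, read by LC-MS, with a stated time of 15 min, tested at 1 uM, in the presence of a further agent that is not named here; on this read-out lower numbers stand for a less stable compound and higher numbers for a more stable compound:
compound 1, `CC(C)n1nc(-c2ccc3oc(N)nc3c2)c2c(CO)nc(N)nc21`, reported only as a limit: > 95%
compound 2, `CC(C)n1nc(-c2ccc3oc(N)nc3c2)c2c(C#N)nc(N)nc21`, reported only as a limit: > 95%

Compound 1 stands at a limit of this assay, so no number is known for it, only that it lies at the ceiling of the read-out. Going by the values given here, the one measured step, a step that the two limits leave unreadable from compound 1 to compound 2, cannot be sized because both ends sit at the limit of > 95% in this assay, at which 2 of the 2 values shown sit. That step exchanges a hydroxymethyl for a cyano group on the same aromatic carbon of the shared core, and the read-out did not move off its ceiling.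

Compound 3, `CC(C)n1nc(-c2ccc3oc(N)nc3c2)c2c(N)nc(N)nc21`, differs from compound 1 by amino in place of hydroxymethyl on an aromatic carbon. Among the compounds with values here, the only comparison at hand, from compound 1 to compound 2, changed the same position without leaving the limit, so the expected step of a number at least 1 percentage points lower from compound 1 to compound 3 (that floor lies within the scatter) is none beyond the scatter. Compound 3 is therefore expected to give about 94% in this assay, within a range of 80% to 99%, most likely again reported only as a limit.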

Compound 3, percent of the compound remaining: > 95%
Compound 3: a limit, no number; the forecaster's own chance of this, stated with the estimate: 60%; at least 1 percentage points between middle value and limit.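

In this assay compound 3 gives > 95%, which is a limit and not a number. No step among compound 1, compound 2 and compound 3 can be read, because all three sit at the same limit: the limit of > 95% in this assay, at which 3 of the 3 values shown sit.

The compounds shown leave open whether hydroxymethyl, cyano and amino on this carbon differ at all in this assay.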